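The compounds below may be only part of what the source reports. "The series", "measured", "known", "first", "only" and "open" are said of these compounds alone.

Compound 1 `O=C(Nc1nccs1)c1cccc(Nc2ncc(F)c(Nc3ccc(F)cc3)n2)c1`: > 10000 nM (a limit)
Compound 2 `O=C(c1cccc(Nc2ncc(F)c(Nc3ccc(F)cc3)n2)c1)N1CCCCC1`: 13800 nM

Among the measured compounds shown here, in a functional assay on KBVIN cells (Homo sapiens) for antiproliferative activity, read by sulforhodamine B assay, with a stated time of 3 days (a higher number here means a weaker inhibitor of growth, a lower number a stronger inhibitor of growth), compound 2 gives 13800 nM, the only true number so far. Compound 1 reads > 10000 nM, which is a limit of the assay and not a number. That leaves compound 2 without a measured neighbour to rank it against.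

The next compound, compound 3 `CN1CCC(C(=O)Nc2cccc(Nc3ncc(F)c(Nc4ccc(F)cc4)n3)c2)CC1`, has not yet been measured. Its difference from compound 2 is this: ((1-methylpiperidin-4-yl)carbonyl)amino in place of (piperidin-1-yl)carbonyl on an aromatic carbon. The group on the aromatic carbon is replaced, while the rest of the molecule stays the same.

For the measured compounds named here, only one measured step exists, a step that the limit leaves unreadable from compound 1 to compound 2. It involves a different change and gives no size to carry over, so no step beyond the usual scatter is expected in this assay, and no direction can be argued with confidence. Compound 3 could also end at a limit, as compound 1 did: the limit of > 10000 nM in this assay, at which 1 of the 2 values shown sits.

The expected change is a 1.5-fold lower number from compound 2 to compound 3 (0.19 log units; within the scatter). For compound 3 the estimate is 9000 nM, with an expected range from 2500 nM to 30000 nM.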

Compound 3, concentration for 50% growth inhibition: 11900 nM
Estimate against measurement, compound 3: 1.3-fold (0.12 log units) below; measured number inside the range.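

In this assay, among the compounds shown here, putting ((1-methylpiperidin-4-yl)carbonyl)amino in place of (piperidin-1-yl)carbonyl gives a 1.2-fold lower number from compound 2 to compound 3 (0.06 log units; within the scatter), the first step at this position that can be read. The exchange is not a small one on paper: the group now joins the aromatic carbon through its amino nitrogen instead of its carbonyl carbon, and it has 1 hydrogen-bond donor where the departing group has 0 hydrogen-bond donors, yet the two compounds cannot be told apart in this test. Compound 1 reads > 10000 nM, which is a limit and not a number, so the steps from compound 1 to compound 2 and to compound 3 cannot be read: the limit of > 10000 nM in this assay, at which 1 of the 3 values shown sits.

Still open, on these data alone, is whether a carboxylic acid, a primary amine or a longer chain on this same aromatic carbon would give a step beyond the usual scatter. The fluorine atoms of the shared core are the same in all the compounds shown, so the effect of replacing them with chlorine or hydrogen is open as well.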